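From a Guanidine Side Chain to an Isopropyl Group

The source may report more compounds than this note shows. Statements on the series, on what has been measured and on what is new or still open speak of the compounds shown alone.

Of the compounds shown here, three have been measured in a functional assay on the whole organism (Tail, strain ICR) with Mus musculus as the target, in the tail flick test, with a stated time of 90 min, at a dose of 25 umol/kg by the oral route; on this read-out higher numbers stand for a stronger effect at the one dose given and lower numbers for a weaker effect. Compound 1, `N=C(N)NCCC[C@H](NC(=O)CN(c1ncnc2c1ncn2C1CCCCO1)C1CC1)C(=O)OCc1ccccc1`, gives 61.6%, the highest of the three numbers. Compound 3, `C[C@H](NC(=O)CN(c1nc(Cl)nc2[nH]cnc12)C1CC1)C(=O)O`, gives 43.5%, and compound 2, `O=C(CN(c1nc(Cl)nc2[nH]cnc12)C1CC1)N[C@@H](CC(=O)OCc1ccccc1)C(=O)OCc1ccccc1`, gives 15.6%; both gaps to compound 1 lie beyond the usual scatter, so compound 1 is the most active of the three measured compounds. Compound 4, `CC(C)[C@H](NC(=O)CN(c1ncnc2c1ncn2C1CCCCO1)C1CC1)C(=O)OCc1ccccc1`, has not yet been measured in this assay. It differs from compound 1 in one place: a group of 3 heavy atoms (3 carbon; no ring) in place of a group of 7 heavy atoms (4 carbon, 3 nitrogen; no ring), on a saturated chain carbon bound to an amide-type nitrogen and a carbonyl carbon. Among the compounds with values here, no pair of measured compounds differs in only one place, so no direct guide to this step exists. A fall in activity beyond the scatter is expected, with the step of a number 21.6 percentage points lower from compound 1 to compound 4 (beyond the scatter). Compound 4 is therefore estimated at 40%, within a range from 15% to 65%.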

Compound 4, a percentage reported as activity, at one dose (the size of the read-out at that dose, not a potency): 30.1%
Compound 4: middle estimate off by 9.9 percentage points, on the high side, and the stated range covers the measured number.
By their numbers in this assay, from the lowest: compound 2; then compound 4; then compound 3; then compound 1.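

Within the data shown here, this is the first pair that differs in one place, and it shows that the group on this saturated chain carbon matters: in this assay, replacing the seven-heavy-atom side chain, which carries 3 hydrogen-bond donors, with isopropyl gives a number 31.5 percentage points lower from compound 1 to compound 4 (beyond the scatter). Activity is reduced but not lost with isopropyl here. Nothing measured here gives the reason for the fall. Still open, going by these compounds, is whether the nitrogens or the chain length matter more. A primary amine at the end of a chain, or a longer plain carbon chain, could separate the two.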